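This account rests on a few compounds, and the source may have more. Where it says the series, first, only, none or still open, it means among the compounds named here.

In a functional assay on M14 cells (Homo sapiens) for inhibition, read by sulforhodamine B assay, with a stated time of 48 h, tested at 10 uM (on this read-out lower numbers stand for a stronger effect and higher numbers for a weaker effect at the one concentration tested), compound 1 `COc1cc2cc(Oc3ccc(NC(=O)Nc4cccc(C(F)(F)F)c4)cc3)c(C)nc2cc1OC` gives 22.7%. Compound 2 `COc1cc2cc(Oc3ccc(NC(=O)Nc4ccc(Cl)c(C(F)(F)F)c4)cc3)c(C)nc2cc1OC` gives -73.7% in this assay, the lowest of the two numbers available, with compound 1 as its nearest neighbour. Among the compounds with values here, the only measured step, a number 96.4 percentage points lower from compound 1 to compound 2 (beyond the scatter), is large and beyond the scatter.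

Compound 3 `COc1cc2cc(Oc3ccc(NC(=O)Nc4ccc(Cl)c(Cl)c4)cc3)c(C)nc2cc1OC` is next. Compared with compound 2 the change is chloro in place of trifluoromethyl on an aromatic carbon. Within the data shown here, no measured step covers this exchange: the one step known swaps hydrogen for chloro, not trifluoromethyl for chloro, so it gives only an indirect hint that a chloro at this place sits well with a strong effect. Keeping a chloro beside the existing chloro, but losing the trifluoromethyl, is expected to leave the strong effect of compound 2 largely in place, with a step of a number 23.7 percentage points higher from compound 2 to compound 3 (beyond the scatter) that may be a modest weakening or none beyond the scatter. Compound 3 is therefore estimated at -50%, within -95% to 0%.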

Compound 3, a percentage reported as activity, at one concentration (the size of the read-out at that concentration, not a potency): 25.8%
Estimate against measurement, compound 3: 75.8 percentage points below; measured number outside the range, above it.
By their numbers in this assay, from the lowest: compound 2; then compounds 1 and 3 (each within the scatter of the next).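

In this assay, chloro in place of trifluoromethyl on this aromatic carbon, ortho to a chloro group, gives a number 99.5 percentage points higher from compound 2 to compound 3 (beyond the scatter), so the strong effect of compound 2 does not survive the exchange. Chloro therefore does not stand in for trifluoromethyl here, and the 3,4-dichlorophenyl group of compound 3 performs on a level with the 3-(trifluoromethyl)phenyl group of compound 1, with a number 3.1 percentage points higher from compound 1 to compound 3 (within the scatter). Among these three compounds, the strong effect appears only in compound 2, the one that carries chloro and trifluoromethyl together on this ring.

Nothing available explains why this exchange matters so much. From the compounds shown here alone, whether bromo, methyl or a nitrile on this carbon would keep the strong effect of compound 2 remains open.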